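Swapping the aromatic ring for a propyl chain on the shared core

The compounds below may be only part of what the source reports. "The series", "measured", "known", "first", "only" and "open" are said of these compounds alone.

Measured compounds and their values:
- compound 1 `CC(=O)OC[C@H]1O[C@@H](n2cc(CN3C(=O)/C(=C/C=C/c4ccccc4)c4ccccc43)nn2)[C@H](OC(C)=O)[C@@H](OC(C)=O)[C@@H]1OC(C)=O`: 17100 nM
- compound 2 `CC(=O)OC[C@H]1O[C@@H](n2cc(CN3C(=O)/C(=C/c4cccs4)c4ccccc43)nn2)[C@H](OC(C)=O)[C@@H](OC(C)=O)[C@@H]1OC(C)=O`: 23400 nM
- compound 3 `CC(=O)OC[C@H]1O[C@@H](n2cc(CN3C(=O)/C(=C/c4ccco4)c4ccccc43)nn2)[C@H](OC(C)=O)[C@@H](OC(C)=O)[C@@H]1OC(C)=O`: 10000 nM

The three measured compounds share one core and differ only in the group on a double-bonded chain carbon bound to a double-bonded ring carbon. In a functional assay on DU-145 cells (Homo sapiens) for cytotoxicity, read by sulforhodamine B assay, with a stated time of 48 h (on this read-out higher numbers stand for weaker inhibition and lower numbers for stronger inhibition), compound 3 gives the lowest of the three numbers. One of the steps is a 1.7-fold lower number from compound 1 to compound 3 (0.23 log units; within the scatter), which stays within the scatter, while another is a 2.3-fold lower number from compound 2 to compound 3 (0.37 log units; beyond the scatter), just beyond it. The step of a 1.4-fold higher number from compound 1 to compound 2 (0.14 log units; within the scatter) likewise stays within the scatter.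

Compound 4 `CCC/C=C1/C(=O)N(Cc2cn([C@@H]3O[C@H](COC(C)=O)[C@@H](OC(C)=O)[C@H](OC(C)=O)[C@H]3OC(C)=O)nn2)c2ccccc21` is not yet measured. It differs from compound 3 in one place: propyl in place of furan-2-yl on a double-bonded chain carbon bound to a double-bonded ring carbon. Within the data shown here, every measured step so far exchanged one ring-bearing group for another, and each of those moves was within the scatter or modest at best. Among the measured compounds shown here, none of them replaced a ring with a chain, so the measured steps give only a loose guide here; a flat chain-bearing group of this size has no precedent among the three compounds, and a weaker result cannot be ruled out.

Taking compound 3 as the anchor, compound 4 is expected to land at 20000 nM, with a range from 7000 nM to 60000 nM. This estimate means a step of a 2.0-fold higher number from compound 3 to compound 4 (0.30 log units; within the scatter), a modest rise in the number, though a result within the scatter would not surprise.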

Compound 4, half-maximal inhibitory concentration: 19700 nM
Compound 4: the middle estimate sits 1.0-fold (0.01 log units) above what was measured; the range from low to high includes it.
By their numbers in this assay, from the lowest: compounds 3, 1, 4 and 2 (each within the scatter of the next, the first and the last beyond it).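

In this assay, the ring-free propyl group fits this place on the shared core as well as any of the ring-bearing groups do, for a 2.0-fold higher number from compound 3 to compound 4 (0.29 log units; within the scatter) and a 1.2-fold lower number from compound 2 to compound 4 (0.07 log units; within the scatter) and a 1.2-fold higher number from compound 1 to compound 4 (0.06 log units; within the scatter) all stay within the scatter. So the furan-2-yl ring, with its hetero atom and hydrogen-bond acceptor, can give way to a plain carbon chain with no change that can be told apart here, and an aromatic ring on the double-bonded chain carbon is not required for a number of this size. Among these compounds, compound 4 also lies within the scatter of both compound 2 and compound 3, even though those two are separated by a 2.3-fold lower number from compound 2 to compound 3 (0.37 log units; beyond the scatter) and so form the only pair here with a gap beyond the scatter, and no evidence is available on what lies behind any of these numbers.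

The compounds shown leave open whether a longer chain such as hexyl, or a short chain ending in an amine or a carboxylic acid, would stay in this same range. They also leave open whether a bare hydrogen or a single methyl on the double-bonded chain carbon would still give numbers like these, since every group so far carries several carbons.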